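A few compounds are considered here, and "the series" means these few. Any claim that something is new, unique, unknown or untested is made for them only; others in the source may bear on it.

In a functional assay on HeLa cells (Homo sapiens) for antiproliferative activity, read by MTT assay, with a stated time of 48 h (on this read-out higher numbers stand for weaker inhibition and lower numbers for stronger inhibition), compound 1 `CCNCC(=O)Nc1cc(OC)ccc1C(=O)c1cc(OC)c(OC)c(OC)c1` gives 2100 nM while compound 2 `COc1ccc(C(=O)c2cc(OC)c(OC)c(OC)c2)c(NC(=O)CN(C)C)c1` gives 470 nM and so holds the lower of the two numbers. Compound 3 `COc1ccc(C(=O)c2cc(OC)c(OC)c(OC)c2)c(NC(=O)CN)c1` differs from compound 2 by amino in place of dimethylamino on a saturated chain carbon bound to a carbonyl carbon with amino in place of dimethylamino on a saturated chain carbon bound to a carbonyl carbon. For the measured compounds named here, the only measured step that bears on this is a 4.5-fold lower number from compound 1 to compound 2 (0.65 log units; beyond the scatter) for dimethylamino in place of ethylamino at that same place, a modest step beyond the scatter. From that step a change of similar modest size toward a higher number is expected, estimated as a 3.2-fold higher number from compound 2 to compound 3 (0.50 log units; beyond the scatter) in this assay for the new amino group. For compound 3 the estimate is 1500 nM within an expected range of 450 nM to 5500 nM on this read-out.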

Compound 3, half-maximal inhibitory concentration: 130 nM
Estimate against measurement, compound 3: 12-fold (1.06 log units) above; the whole stated range lies above it.
By their numbers in this assay, from the lowest: compound 3; then compound 2; then compound 1.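

In this assay, stripping the carbon groups from the amine nitrogen gives a 3.6-fold lower number from compound 2 to compound 3 (0.56 log units; beyond the scatter) and a 16-fold lower number from compound 1 to compound 3 (1.21 log units; beyond the scatter) as a large step. The gain seen with dimethylamino over ethylamino therefore did not mean that more carbon on this nitrogen helps: among the three compounds, the plain amino group on a saturated chain carbon bound to a carbonyl carbon holds the lowest number. Nothing available explains this order.

On these data alone, whether methylamino, a hydroxyl group or a carboxylic acid at this place would give a still lower number remains open.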